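The source may hold more compounds than are shown below. What is called first, only, known or untested is meant among the compounds shown, and "the series" means these compounds.

Working notes on the series, measured in a functional assay on MCF7 cells (Homo sapiens) for cytotoxicity, read by MTT assay, with a stated time of 72 h; on this read-out lower numbers stand for stronger inhibition and higher numbers for weaker inhibition:

- compound 1 `Cc1c(C)c2c(c(C)c1OC(=O)CCC(=O)O)CCC(C)(C(=O)O)O2`: > 300000 nM (a limit, not a number)
- compound 2 `Cc1c(C)c2c(c(C)c1O)CCC(C)(C(=O)NC1CC(C)(C)N([O])C1(C)C)O2`: 58000 nM
- compound 3 `Cc1c(C)c2c(c(C)c1OC(=O)CCC(=O)NC1CC(C)(C)N([O])C1(C)C)CCC(C)(C(=O)NC1CC(C)(C)N([O])C1(C)C)O2`: 86000 nM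

Compound 3, at 86000 nM, lies within the scatter of compound 2, at 58000 nM. Among the compounds with values here, these are the only two true numbers.

Compound 4 `Cc1c(C)c2c(c(C)c1OC(=O)CCC(=O)O)CCC(C)(C(=O)NC1CC(C)(C)N([O])C1(C)C)O2` differs from compound 3 on a carbonyl carbon: one oxygen atom in place of a group of 11 heavy atoms (8 carbon, 2 nitrogen, 1 oxygen; one five-membered non-aromatic ring with 1 hetero atom), on a carbonyl carbon. The group that enters there is a hydroxy, which leaves an acid-ending ester chain on the core. Within the data shown here, no measured pair differs in one place, so the expectation rests on the neighbours. Compound 1 carries the same acid-ending chain, and its > 300000 nM is a limit. Compound 4 keeps the ring-bearing amide that compound 2 also carries, and compound 2 gives 58000 nM.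

In this assay the expected step is small and towards weaker inhibition, a 1.3-fold higher number from compound 3 to compound 4 (0.11 log units; within the scatter), and it may not clear the scatter. For compound 4 the estimated value is 110000 nM, with an expected range of 50000 nM to 280000 nM.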

Compound 4, half-maximal inhibitory concentration: > 300000 nM
Compound 4: no number, only a limit; the forecaster's own chance of this, stated with the estimate: 25%; middle value at least 2.7-fold (0.43 log units) from the limit.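

In this assay, hydroxy in place of the group of 11 heavy atoms on this carbonyl carbon gives an at least 3.4-fold higher number from compound 3 to compound 4 (0.54 log units; beyond the scatter), and (2-carboxyethyl)carbonyl in place of hydrogen on an oxygen on an aromatic ring gives an at least 5.1-fold higher number from compound 2 to compound 4 (0.71 log units; beyond the scatter). Compound 4 gives > 300000 nM, which is a limit and not a number. The earlier compounds did not show that the ring-bearing amide on the other carbonyl carbon is insufficient to keep a measured number once the chain ends in hydroxy, and the acid-ending chain is common to compound 1 and compound 4, the two compounds at this value: the limit of > 300000 nM in this assay, at which 2 of the 4 values shown sit.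

The step between compound 1 and compound 4 cannot be read, as both values are limits. Going by these compounds, whether a primary amide or a methyl ester on this carbonyl carbon would retain a measured number stays open.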